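This account rests on a few compounds, and the source may have more. Where it says the series, first, only, none or still open, it means among the compounds named here.

The study examines dichloroacetamides carrying an aryl group on the anilide ring. Compound 1 `O=C(Nc1cccc(-c2ccc(F)cc2)c1)C(Cl)Cl` bears a fluorophenyl group. In a functional assay on NCI-H460 cells (Homo sapiens) for cytotoxicity, read by MTT assay, with a stated time of 68 h (a higher number here means a weaker inhibitor, a lower number a stronger inhibitor), compound 1 reports only a limit of > 50000 nM, not a number. Compound 2 `O=C(Nc1cccc(-c2nccs2)c1)C(Cl)Cl` carries a thiazolyl group in the same position. In this assay compound 2 likewise reports only a limit of > 50000 nM. Compound 3 `CCOc1cccc(-c2cc(NC(=O)C(Cl)Cl)cc(-c3cccc(OCC)c3)c2)c1` carries two ethoxyphenyl groups on the central ring. In this assay compound 3 gives a numerical value of 4950 nM, and among the three compounds only compound 3 yields a value that is not a limit. Compound 1 therefore stands at the weak end of what has been shown, at the limit of > 50000 nM in this assay, at which 2 of the 3 values shown sit, and no step between it and a measured compound is available.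

Compound 4 `O=C(Nc1cccc(-c2ccc(Cl)cc2)c1)C(Cl)Cl` is the unmeasured partner of compound 1. The difference is chloro in place of fluoro on an aromatic carbon. With compound 1 sitting at a limit, nothing on hand tells how this change would move the read-out, and the step from a number no higher from compound 1 to compound 4 (the limit leaves the size open) that is expected is none beyond the scatter. Compound 4 is therefore estimated to give about 50000 nM in this assay, within a range from 15000 nM to 200000 nM, most likely again as a limit rather than a number.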

Compound 4, half-maximal inhibitory concentration: > 50000 nM
Compound 4: no number, only a limit; the forecaster's own chance of this, stated with the estimate: 75%; the middle value lies on the limit itself.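

In this assay, going by these compounds alone, compound 4 gives only a limit, as compound 1 does, and no step between compound 1 and compound 4 can be read. The compounds shown leave open whether chloro and fluoro differ at all in this assay here, and which feature of compound 3 alone yields a number.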